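The source may hold more compounds than are shown below. What is called first, only, known or untested is meant among the compounds shown, and "the series" means these compounds.

Compound 1 `COc1ccc(-c2ccc3c(c2)C(=O)C(=O)N3C)cc1` gives 6670 nM in a functional assay on HepG2 cells (Homo sapiens) for antiproliferative activity, read by MTT assay, with a stated time of 48 h; a lower number here means a stronger inhibitor, a higher number a weaker inhibitor. Compound 2 `COc1ccc(-c2ccc3c(c2)C(=O)C(=O)N3Cc2ccc(Cl)cc2)cc1` gives 250 nM. Compound 3 `COc1ccc(CN2C(=O)C(=O)c3cc(-c4ccc(C(C)(C)C)cc4)ccc32)cc1` gives 4580 nM.

Among these three numbers compound 3 stands second highest: its nearest neighbour is compound 1, within the usual scatter, and its furthest is compound 2, beyond it. Compound 4 `COc1ccc(CN2C(=O)C(=O)c3cc(-c4ccc5ccccc5c4)ccc32)cc1` has not been measured. It differs from compound 3 in one place: naphthalen-2-yl in place of 4-(tert-butyl)phenyl on an aromatic carbon. Among the measured compounds shown here, the only measured step, a 27-fold lower number from compound 1 to compound 2 (1.43 log units; beyond the scatter), concerns the group on a saturated chain carbon bound to an amide-type nitrogen in a ring, not the aromatic carbon changed here, so it does not bear on this step. For the measured compounds named here, with no measured step at that position, a change no larger than the scatter is expected in this assay, in either direction, a 1.1-fold lower number from compound 3 to compound 4 (0.06 log units; within the scatter). Compound 4 is therefore estimated at 4000 nM, with a range from 1500 nM to 12000 nM.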

Compound 4, half-maximal inhibitory concentration: > 10000 nM
Compound 4: no number, only a limit (the forecaster's own chance of this, stated with the estimate: 5%); middle value at least 2.5-fold (0.39 log units) away from the limit.
By their numbers in this assay, from the lowest: compound 2; then compounds 3 and 1 (each within the scatter of the next). At a limit, above all of these: compound 4.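

The earlier compounds shown here gave no measured step at this aromatic carbon, and here the position responds in this assay: naphthalen-2-yl in place of 4-(tert-butyl)phenyl brings an at least 2.1-fold higher number from compound 3 to compound 4 (0.33 log units; beyond the scatter). The two groups match in heavy atoms and differ in their count of aromatic rings, so the heavy-atom count alone does not set the number. Compound 4 has only a limit of the assay, so the full size of the step stays unknown: the limit of > 10000 nM in this assay, at which 1 of the 4 values shown sits.

Going by these compounds, whether a 4-aminophenyl or 4-carboxyphenyl group on this carbon would lower the number remains open. Also open, on these data alone, is whether this step would hold with 4-chlorophenyl on the saturated chain carbon.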